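The compounds below may be only part of what the source reports. "The series", "measured", "known", "first", "only" and "open" are said of these compounds alone.

Working notes on a small urea series on a shared core, read in a functional assay on CRL2813 cells (Homo sapiens) for cytotoxicity, read by sulforhodamine B assay, with a stated time of 5 days; a higher number here means a weaker inhibitor, a lower number a stronger inhibitor. Compound 1 `O=C(Nc1cccc([N+](=O)[O-])c1)N[C@H]1CC[C@H](Oc2ccc(F)cc2)CC1` gives 6700 nM in this assay, the lowest of the two numbers in hand. Compound 2 `O=C(Nc1ccccc1Br)N[C@H]1CC[C@H](Oc2ccc(F)cc2)CC1` gives 7700 nM in this assay; the step of a 1.1-fold higher number from compound 1 to compound 2 (0.06 log units; within the scatter) lies within the scatter, so no order between compound 1 and compound 2 can be read from these two values. Compound 3 `O=C(Nc1ccccc1Cl)N[C@H]1CC[C@H](Oc2ccc(F)cc2)CC1` is not yet measured. It differs from compound 1 in one place: 2-chlorophenyl in place of 3-nitrophenyl on an amide-type nitrogen. Going by the values given here, the only measured step that bears on this change is the one where 2-bromophenyl entered for 3-nitrophenyl on an amide-type nitrogen, a 1.1-fold higher number from compound 1 to compound 2 (0.06 log units; within the scatter), a step within the scatter. The change to compound 3 is of the same kind, so no step beyond the scatter is expected in this assay. Compound 3 is therefore estimated at 7500 nM in this assay, with a range from 3500 nM to 16000 nM. The expected step is a 1.1-fold higher number from compound 1 to compound 3 (0.05 log units; within the scatter).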

Compound 3, half-maximal inhibitory concentration: 9100 nM
The estimate for compound 3 lay 1.2-fold (0.08 log units) below the measured number, and the stated range covers the measured number.
By their numbers in this assay, from the lowest: compounds 1, 2 and 3 (each within the scatter of the next).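

With a second group in place of 3-nitrophenyl on the amide-type nitrogen, this assay again shows no readable shift: 2-chlorophenyl gives (a 1.4-fold higher number from compound 1 to compound 3 (0.13 log units; within the scatter)). The new compound also permits a direct exchange of one halogen for the other on an aromatic carbon, a change the earlier pair could not show, and chloro in place of bromo gives (a 1.2-fold higher number from compound 2 to compound 3 (0.07 log units; within the scatter)), so these two compounds cannot be ordered. No measurement in hand bears on the cause of either step.

Going by these compounds, it remains open whether any group on this nitrogen can move the number beyond the scatter, for example a straight alkyl chain or a phenyl ring carrying a carboxylic acid or an amine. Also open, on these data alone, is whether any change outside this place, in the shared core, would do so.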